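The source may report more compounds than this note shows. Statements on the series, on what has been measured and on what is new or still open speak of the compounds shown alone.

Compound 3, `Cc1ncc([N+](=O)[O-])n1CCOC(=O)c1cc(NC(=O)[C@H](C)NC(=O)OCc2ccccc2)ccc1O`, stands second highest of the three numbers in a functional assay on the whole organism (strain Wistar) for inhibition, with Rattus norvegicus as the target, read by paw edema, with stated times of 1 h and 4 h, at a dose of 10 mg/kg by the intraperitoneal route (a lower number here means less inhibition, a higher number more inhibition at the dose given (going by the name of the read-out)), where compound 3 gives 36.1%. Compound 1, `Cc1ncc([N+](=O)[O-])n1CCOC(=O)c1cc(NC(=O)C(C)NC(=O)OCc2ccccc2)ccc1O`, gives 41.1%, and a number 5 percentage points lower from compound 1 to compound 3 (within the scatter); the pair differs only at one stereocentre, (the fact that one of compounds 1 and 3 is drawn with a defined configuration and the other without, at the place where they differ). Compound 2, `CC(=O)Nc1ccc(O)c(C(=O)OCCn2c([N+](=O)[O-])cnc2C)c1`, gives 15.5%, the lowest of the three. Compound 4, `Cc1ncc([N+](=O)[O-])n1CCOC(=O)c1cc(NC(=O)[C@H](CCCCN)NC(=O)OCc2ccccc2)ccc1O`, differs from compound 3 by 3-aminopropyl in place of hydrogen on a saturated chain carbon, two bonds along the chain from an amide-type nitrogen and a carbonyl carbon. For the measured compounds named here, only one measured step touches that saturated chain carbon, a number 5 percentage points lower from compound 1 to compound 3 (within the scatter), and it lies within the scatter, so no measured step tells how a larger substituent there would read. The sensible expectation is a step of no certain direction and no size beyond the scatter. Compound 4 is therefore expected to give 37%, between 22% and 52%. This estimate means an expected a number 0.9 percentage points higher from compound 3 to compound 4 (within the scatter).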

Compound 4, a percentage reported as inhibition, in the whole organism at one dose (the size of the read-out at that dose, not a potency): 33.5%
Beside the measured number, compound 4's estimate is 3.5 percentage points above it; the measured number falls inside the stated range.
By their numbers in this assay, from the lowest: compound 2; then compounds 4, 3 and 1 (each within the scatter of the next).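

In this assay, methyl giving way to 4-aminobutyl on the saturated chain carbon gives a number 2.6 percentage points lower from compound 3 to compound 4 (within the scatter). For the compounds shown here, this is the first reading at this carbon of a group other than methyl, and it shows that a chain ending in an amine can stand there with no step beyond the scatter. Nothing known here bears on the reason for this result. The compounds shown leave open whether a carboxylic acid at the chain end, a benzyl group or a longer chain on this carbon would read the same.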